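Halogen Series on the Shared Core: Cytotoxicity Notes

This account rests on a few compounds, and the source may have more. Where it says the series, first, only, none or still open, it means among the compounds named here.

Measured so far in an ADME assay on L02 cells (Homo sapiens) for cytotoxicity, read by MTT assay, with a stated time of 48 h; a lower number here means a stronger inhibitor, a higher number a weaker inhibitor:
- compound 1, `Cc1ccc2[nH]c(=O)c(-c3nc4ccccc4[nH]3)cc2c1`: > 100000 nM
- compound 2, `Cc1ccc2[nH]c(=O)c(-c3nc4cc(F)ccc4[nH]3)cc2c1`: > 100000 nM
- compound 3, `Cc1ccc2[nH]c(=O)c(-c3nc4cc(Cl)ccc4[nH]3)cc2c1`: > 100000 nM

Each of these three numbers is a limit of this assay and not a measured value; compound 3 therefore stands only at a limit, with no number of its own. The other two values are limits as well, all three sitting at the limit of > 100000 nM in this assay, at which 3 of the 3 values shown sit. Accordingly the three steps between them cannot be read: a step that the two limits leave unreadable from compound 1 to compound 2, a step that the two limits leave unreadable from compound 1 to compound 3 and a step that the two limits leave unreadable from compound 2 to compound 3 are all unreadable in size and direction.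

Compound 4, `Cc1ccc2[nH]c(=O)c(-c3nc4cc(Br)ccc4[nH]3)cc2c1`, is not yet measured. It differs from compound 3 by bromo in place of chloro on an aromatic carbon. Within the data shown here, the steps that bear on this change are the halogen exchanges on the same aromatic carbon of the shared core, and none of them yields a readable size in this assay.

On that basis no step beyond the scatter is expected; the expected step is a step that the limit leaves unreadable from compound 3 to compound 4. Compound 4 is therefore estimated in this assay at 150000 nM, within a range of 60000 nM to 400000 nM, most probably reported again as a limit.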

Compound 4, half-maximal inhibitory concentration: > 100000 nM
Compound 4 was reported as a limit (the forecaster's own chance of this, stated with the estimate: 80%); the middle value is on the limit's open side.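

In this assay compound 4 gives > 100000 nM, which is a limit and not a measured value. The steps to compound 4 from compound 1, compound 2 and compound 3 therefore cannot be read in size or direction: the limit of > 100000 nM in this assay, at which 4 of the 4 values shown sit.

The compounds shown leave open whether hydrogen, fluoro, chloro and bromo at this place differ at all in this assay.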